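Phenyl for Ethyl on the Ester Oxygen of Compound 3

A few compounds are considered here, and "the series" means these few. Any claim that something is new, unique, unknown or untested is made for them only; others in the source may bear on it.

Three measured compounds share one core and differ only in the group attached to one aromatic carbon. Compound 1 `CN(C)c1ccc(-c2cccc([N+](=O)[O-])c2)cc1` carries a nitro group there, and in an assay on COS-7 cells for inhibition of patatin-like phospholipase domain-containing protein 2 (Mus musculus), tested at 200 uM (a lower number here means less inhibition, a higher number more inhibition at the concentration tested (going by the name of the read-out)), compound 1 gives 21%. Compound 2 `COC(=O)Nc1cccc(-c2ccc(N(C)C)cc2)c1` carries a (methoxycarbonyl)amino group and gives 95%; compound 3 `CCOC(=O)Nc1cccc(-c2ccc(N(C)C)cc2)c1` carries an (ethoxycarbonyl)amino group and gives 93%. Among these three numbers compound 3 stands second highest, separated from compound 2 by a number 2 percentage points lower from compound 2 to compound 3 (within the scatter) and from compound 1 by a number 72 percentage points higher from compound 1 to compound 3 (beyond the scatter), while a number 74 percentage points higher from compound 1 to compound 2 (beyond the scatter) shows the same large rise for compound 2.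

Compound 4 `CN(C)c1ccc(-c2cccc(NC(=O)Oc3ccccc3)c2)cc1` is not yet measured; it differs from compound 3 by phenyl in place of ethyl on an oxygen next to a carbonyl group. Within the data shown here, the only measured step at this oxygen, a number 2 percentage points lower from compound 2 to compound 3 (within the scatter), was small, and both steps from the nitro compound were large, so the high inhibition seems to rest on the (alkoxycarbonyl)amino part rather than on the chain beyond the oxygen. Among the measured compounds shown here, no measured compound shows what an aromatic ring does in this place, so the expectation is a modest fall at most. Compound 4 is expected to give 88%, with a range from 65% to 98%. This estimate means an expected step of a number 5 percentage points lower from compound 3 to compound 4 (within the scatter).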

Compound 4, a percentage reported as inhibition, at one concentration (the size of the read-out at that concentration, not a potency): 75%
Estimate against measurement, compound 4: 13 percentage points above; measured number inside the range.
By their numbers in this assay, from the lowest: compound 1; then compound 4; then compounds 3 and 2 (each within the scatter of the next).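

Phenyl in place of ethyl on an oxygen next to a carbonyl group brings a number 18 percentage points lower from compound 3 to compound 4 (beyond the scatter) in this assay, and phenyl in place of methyl brings a number 20 percentage points lower from compound 2 to compound 4 (beyond the scatter) at the same place. The group on this oxygen therefore does affect the read-out, which the step of a number 2 percentage points lower from compound 2 to compound 3 (within the scatter) alone did not reveal. Even so, compound 4 gives 75% and the nitro-bearing compound 1 gives 21%, and no available evidence explains the change brought by phenyl.

From the compounds shown here alone, whether the lower number goes with the aromatic ring or simply with the larger group remains open. A cyclohexyl group, a benzyl group or a longer chain such as butyl on this oxygen would help separate these two readings.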